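Swapping an Acetamide Tail for an Aldehyde End

The source may hold more compounds than are shown below. What is called first, only, known or untested is meant among the compounds shown, and "the series" means these compounds.

Three measured compounds share one core and differ only in the long chain attached to it. In a functional assay on COLO 205 cells (Homo sapiens) for antiproliferative activity (on this read-out lower numbers stand for stronger inhibition of growth and higher numbers for weaker inhibition of growth), compound 1 `CCCCCOCCCCCCC/C=C1\CC(CO)(COC(=O)C(C)(C)C)OC1=O` gives 0.491 ug/mL. Compound 2 `CCCCCCCCC(O)CCCCCC/C=C1\CC(CO)(COC(=O)C(C)(C)C)OC1=O` gives 8.91 ug/mL in this assay, and compound 3 `CC(=O)NCCCCCCCCCCCCCCC/C=C1\CC(CO)(COC(=O)C(C)(C)C)OC1=O` gives 4.74 ug/mL. Compound 3 thus stands second highest of the three numbers: its gap to compound 2 lies within the scatter, while its gap to compound 1 lies beyond it. Both measured steps start from compound 1: an 18-fold higher number from compound 1 to compound 2 (1.26 log units; beyond the scatter), and a 9.7-fold higher number from compound 1 to compound 3 (0.98 log units; beyond the scatter). Each of these changes to the chain made growth inhibition weaker.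

Compound 4 `CC(C)(C)C(=O)OCC1(CO)C/C(=C\CCCCCCCCCCCCCCC=O)C(=O)O1` has not yet been tested. For the measured compounds named here, its difference from compound 3 is formyl in place of acetamidomethyl on a saturated chain carbon, ten or more bonds along the chain from a double-bonded chain carbon No measured step covers this change; the two known steps only show that altering the chain of compound 1 raised the number, and they give no guide for trading acetamidomethyl for formyl. Compound 4 is therefore expected near compound 3, at an estimated 3.5 ug/mL, with a range from 1 ug/mL to 12 ug/mL. The expected step is a 1.4-fold lower number from compound 3 to compound 4 (0.13 log units; within the scatter), that is, no change beyond the scatter is anticipated.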

Compound 4, concentration for 50% growth inhibition: > 10 ug/mL
Compound 4 ended at the assay's limit; the forecaster's own chance of this, stated with the estimate: 5%; at least 2.8-fold (0.45 log units) between middle value and limit.
By their numbers in this assay, from the lowest: compound 1; then compounds 3 and 2 (each within the scatter of the next). At a limit, above all of these: compound 4.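

Compound 4 sits at a limit of the assay, so its entry is a limit and not a number: the limit of > 10 ug/mL in this assay, at which 1 of the 4 values shown sits. Even read as a floor, the result gives an at least 2.1-fold higher number from compound 3 to compound 4 (0.32 log units; beyond the scatter), so at this place, on a saturated chain carbon, formyl in place of acetamidomethyl weakens growth inhibition by more than the scatter. Compound 1 keeps the lowest number, with an at least 20-fold higher number from compound 1 to compound 4 (1.30 log units; beyond the scatter), which makes this a third chain change that moves away from compound 1, whereas an at least 1.1-fold higher number from compound 2 to compound 4 (0.05 log units; that floor lies within the scatter) has a floor too small to separate those two compounds.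

From the compounds shown here alone, how far compound 4 lies past the limit stays open, and so does whether it truly differs from compound 2. The compounds shown also leave open what a carboxylic acid or an amine at the end of this chain would give in this assay, and whether a longer chain carrying formyl would bring the number back towards that of compound 1.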